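A few compounds are considered here, and "the series" means these few. Any claim that something is new, unique, unknown or untested is made for them only; others in the source may bear on it.

Compound 1 `CCn1c(/C=C2\SC(=O)N(CC(=O)N3CCCCC3)C2=O)nc2ccccc21` and compound 3 `CC(C)n1c(/C=C2\SC(=O)N(CC(=O)N3CCCCC3)C2=O)nc2ccccc21` share a core, and compound 3 carries the change (methyl in place of hydrogen on a saturated chain carbon bound to an aromatic nitrogen and a saturated chain carbon). In a functional assay on PC-3 cells (Homo sapiens) for inhibition, read by MTT assay, with a stated time of 48 h (a higher number here means a weaker inhibitor, a lower number a stronger inhibitor), compound 1 gives only a limit, > 50000 nM. In this assay compound 3 likewise gives only a limit, > 50000 nM. The step from compound 1 to compound 3 is therefore a step that the two limits leave unreadable from compound 1 to compound 3, and what stands behind both values is the limit of > 50000 nM in this assay, at which 2 of the 3 values shown sit.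

Among the compounds with values here, compound 2 `CCn1c(/C=C2\SC(=O)N(CC(=O)N3CCc4cc(OC)c(OC)cc4C3)C2=O)nc2ccccc21` differs from compound 1 in a way that is not broken down here; in this assay compound 2 gives 33500 nM, the only number among the three measured compounds.

Compound 4 `COc1cc2c(cc1OC)CN(C(=O)CN1C(=O)S/C(=C\c3nc4ccccc4n3C(C)C)C1=O)CC2` has not been measured. It differs from compound 2 by methyl in place of hydrogen on a saturated chain carbon bound to an aromatic nitrogen and a saturated chain carbon, the same kind of change that was made from compound 1 to compound 3, at a place described in the same words. Since that earlier step could not be read, the expectation for compound 4 rests on the value of compound 2, 33500 nM, and on the step from compound 2 to compound 4 being expected to be about a 1.2-fold higher number from compound 2 to compound 4 (0.08 log units; within the scatter). Compound 4 is thus estimated at 40000 nM in this assay, expected to lie between 18000 nM and 100000 nM.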

Compound 4, half-maximal inhibitory concentration: > 50000 nM
Compound 4 ended at the assay's limit; the forecaster's own chance of this, stated with the estimate: 45%; middle value at least 1.2-fold (0.09 log units) from the limit.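

In this assay compound 4 gives > 50000 nM, which is a limit of the assay and not a number. As far as these compounds go, on the core of compound 2, the change from ethyl to isopropyl therefore gives an at least 1.4-fold higher number from compound 2 to compound 4 (0.17 log units; that floor lies within the scatter); only this floor is known, so the true size of the step remains unknown and it may or may not pass beyond the scatter. The same change on the core of compound 1 cannot be read, so there are no two sizes to compare and the data do not show whether the change carries the same size from one core to the other, the reading being capped at one value: the limit of > 50000 nM in this assay, at which 3 of the 4 values shown sit.

Still open, from the compounds shown here alone, is how a longer chain such as butyl, or a benzyl group, would read in this assay in place of the ethyl on the core of compound 2. Also open, going by these compounds, is where compound 3 and compound 4 truly lie, beyond their limits.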